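Working notes: from primary amide to pyrrolidinyl amide

The source may hold more compounds than are shown below. What is called first, only, known or untested is meant among the compounds shown, and "the series" means these compounds.

Measured in a functional assay on A549 cells (Homo sapiens) for cytotoxicity, with a stated time of 60 h; a higher number here means that more compound is needed for the effect, a lower number that less compound is needed:
- compound 1 `CCN(CC)C(=O)c1c(NC(=O)c2cccs2)sc2c1CCCCC2`: 13000 nM
- compound 2 `NC(=O)c1c(NC(=O)c2cccs2)sc2c1CCCC2`: < 30000 nM (a limit)

Compound 2 has no number in this assay, only a limit: the limit of < 30000 nM in this assay, at which 1 of the 2 values shown sits.

The next structure, compound 3 `O=C(Nc1sc2c(c1C(=O)N1CCCC1)CCCC2)c1cccs1`, differs from compound 2 by pyrrolidin-1-yl in place of amino on a carbonyl carbon. Among the compounds with values here, no measured step covers this change. Within the data shown here, the only number available as a guide is compound 1 at 13000 nM, which also has a substituted nitrogen on the carbonyl carbon, so a value near it is expected. The expected size of the step that the limit leaves unreadable from compound 2 to compound 3 is small, towards a lower number in this assay if at all, and hardly beyond the scatter. For compound 3 the estimated value is 15000 nM, with an expected range of 6000 nM to 30000 nM.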

Compound 3, half-maximal effective concentration: 3100 nM
Compound 3: the middle estimate sits 4.8-fold (0.68 log units) above what was measured; the measured number lies below the stated range.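

No step from compound 2 to compound 3 can be read, because compound 2 carries only a limit and not a number: the limit of < 30000 nM in this assay, at which 1 of the 3 values shown sits.

The compounds shown leave open the size and direction of the change when pyrrolidin-1-yl replaces amino on a carbonyl carbon.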